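Replacing the acetyl of compound 3

The source may hold more compounds than are shown below. What is called first, only, known or untested is meant among the compounds shown, and "the series" means these compounds.

Measured so far in an ADME assay (liver) for metabolic stability, with Liver microsome (Rattus norvegicus) as the target, using microsomes and NADPH, with a stated time of 30 min; on this read-out lower numbers stand for slow clearance and higher numbers for fast clearance:
- Compound 1 `CC#CCC(O)(c1ccc(N2CCN(S(=O)(=O)c3ccc(N)nc3)C[C@@H]2C#CC)cc1)C(F)(F)F`: 115 mL.min-1.g-1
- Compound 2 `CC#C[C@H]1CN(S(=O)(=O)c2ccc(N)nc2)CCN1c1ccc(S(C)(=N)=O)cc1`: < 14 mL.min-1.g-1 (a limit of the assay)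
- Compound 3 `CC#C[C@H]1CN(S(=O)(=O)c2ccc(N)nc2)CCN1c1ccc(C(C)=O)cc1`: 249 mL.min-1.g-1

Compound 3 stands highest of the numbers in this assay, with a 2.2-fold higher number from compound 1 to compound 3 (0.34 log units; beyond the scatter) and an at least 17-fold higher number from compound 2 to compound 3 (1.25 log units; beyond the scatter). Compound 4 `CC#C[C@H]1CN(S(=O)(=O)c2ccc(N)nc2)CCN1c1ccc(C(O)(CC#N)C(F)(F)F)cc1` differs from compound 3 by a group of 9 heavy atoms (4 carbon, 1 nitrogen, 1 oxygen, 3 fluorine; no ring) in place of a group of 3 heavy atoms (2 carbon, 1 oxygen; no ring), on an aromatic carbon. Compound 1 offers the closest comparison, since its group of 10 heavy atoms resembles the entering group. Read in reverse, a 2.2-fold higher number from compound 1 to compound 3 (0.34 log units; beyond the scatter) points to a modest fall. The larger at least 8.2-fold lower number from compound 1 to compound 2 (0.91 log units; beyond the scatter) shows that this position can carry a wider change. The expected step is a 4.2-fold lower number from compound 3 to compound 4 (0.62 log units; beyond the scatter), somewhat beyond the modest comparison. Compound 4 is estimated at 60 mL.min-1.g-1, with an expected range from 18 mL.min-1.g-1 to 150 mL.min-1.g-1.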

Compound 4, intrinsic clearance in microsomes: 57 mL.min-1.g-1
Compound 4: middle estimate off by 1.1-fold (0.02 log units), on the high side; measured number inside the range.
By their numbers in this assay, from the lowest: compounds 4 and 1 (each within the scatter of the next); then compound 3. At a limit, below all of these: compound 2.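

In this assay, the acetyl of compound 3 gives way to the nitrile-bearing trifluoromethyl carbinol with a 4.4-fold lower number from compound 3 to compound 4 (0.64 log units; beyond the scatter), so this aromatic position tolerates a carbinol with a chain shorter than that of compound 1. Cyano in place of prop-1-yn-1-yl gives a 2.0-fold lower number from compound 1 to compound 4 (0.30 log units; within the scatter), so the chain end does not separate this pair. Compound 2 stands at a limit of the assay, so an at least 4.0-fold higher number from compound 2 to compound 4 (0.60 log units; beyond the scatter) is a bound only: the limit of < 14 mL.min-1.g-1 in this assay, at which 1 of the 4 values shown sits.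

Which part of the entering group goes with the lower number stays open. So does whether an amine or a carboxylic acid on that chain would approach compound 2.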